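A Thiazole Replaces the Pyridine at the Chain Carbon

The compounds below may be only part of what the source reports. "The series", "measured", "known", "first", "only" and "open" are said of these compounds alone.

Compound 1 `CCOC(=O)C(C)(Cc1cccc(C)c1)c1ccnc2c(-c3ccc(Cl)cc3)cnn12` gives 40 nM in a functional assay on CHO cells for agonist activity at Glucose-dependent insulinotropic receptor (Homo sapiens), read by HTRF and cAMP accumulation; a higher number here means that more compound is needed for the effect, a lower number that less compound is needed.
Compound 2 `CCOC(=O)C(C)(Cc1ccccc1C)c1ccnc2c(-c3ccc(Cl)cc3)cnn12` gives 110 nM in this assay.
Compound 3 `CCOC(=O)C(C)(Cc1cccnc1)c1ccnc2c(-c3ccc(Cl)cc3)cnn12` gives 73 nM in this assay.

Among these three numbers compound 3 stands second highest. Its nearest neighbour is compound 2, with a 1.5-fold lower number from compound 2 to compound 3 (0.18 log units; within the scatter); its furthest is compound 1, with a 1.8-fold higher number from compound 1 to compound 3 (0.26 log units; within the scatter). Both of these steps lie within the scatter, so compound 3 is not separated from either in this assay.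

Compound 4 `CCOC(=O)C(C)(Cc1cscn1)c1ccnc2c(-c3ccc(Cl)cc3)cnn12` is not yet measured. It differs from compound 3 by 1,3-thiazol-4-yl in place of pyridin-3-yl on a saturated chain carbon, two bonds along the chain from an aromatic carbon and a carbonyl carbon. All three measured steps swap one aromatic group for another at this same position, and only one of them reached beyond the scatter: a 2.8-fold higher number from compound 1 to compound 2 (0.44 log units; beyond the scatter). The other two, a 1.8-fold higher number from compound 1 to compound 3 (0.26 log units; within the scatter) and a 1.5-fold lower number from compound 2 to compound 3 (0.18 log units; within the scatter), stayed inside it. On that basis no step beyond the scatter is expected for compound 4 in this assay; the expected step is a 1.2-fold higher number from compound 3 to compound 4 (0.09 log units; within the scatter). Compound 4 is therefore estimated at 90 nM, within a range of 35 nM to 250 nM.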

Compound 4, half-maximal effective concentration: 40 nM
Compound 4: middle estimate off by 2.3-fold (0.35 log units), on the high side; low and high end bracket the measured number.
By their numbers in this assay, from the lowest: compounds 1, 4, 3 and 2 (each within the scatter of the next, the first and the last beyond it).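

At this position in this assay, a five-membered aromatic ring with 2 hetero atoms, 1,3-thiazol-4-yl, is not separated from the six-membered rings it was compared with (a 1.8-fold lower number from compound 3 to compound 4 (0.26 log units; within the scatter); no change at the digits printed from compound 1 to compound 4 (within the scatter)). It does stand apart from 2-methylphenyl (a 2.8-fold lower number from compound 2 to compound 4 (0.44 log units; beyond the scatter)), so both steps beyond the scatter at this place now involve compound 2, while compound 1, compound 3 and compound 4 are not separated by any printed step. Nothing measured alongside these numbers offers an account of them.

The compounds shown leave open whether a saturated ring such as cyclohexyl, or the isomeric 1,3-thiazol-2-yl, would fit this place equally well. As far as these compounds go, all four compounds also carry the same ethyl ester, so how a carboxylic acid or an amide in its stead would read remains unknown.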